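From Hydroxy to Acetoxy: One Small Change Under Test

The source may report more compounds than this note shows. Statements on the series, on what has been measured and on what is new or still open speak of the compounds shown alone.

- compound 1 `Cc1cc(Cl)c2c(c1O)C(=O)C=CC2=O` gives 9400 nM
- compound 2 `CC(=O)Oc1cc(OC(C)=O)c2c(OC(C)=O)c(C)cc(Cl)c2c1OC(C)=O` gives 53500 nM

In a functional assay on SNO cells (Homo sapiens) for cytotoxicity, read by XTT assay, with a stated time of 24 h (a lower number here means a stronger inhibitor, a higher number a weaker inhibitor), compound 1 has the lower number of the two, and the gap to compound 2 lies beyond the usual scatter. Compound 3 `CC(=O)Oc1c(C)cc(Cl)c2c1C(=O)C=CC2=O` has not yet been measured. It differs from compound 1 by one change acetyl in place of hydrogen on an oxygen on an aromatic ring that puts acetyl in place of hydrogen on an oxygen on an aromatic ring, turning hydroxy to acetoxy. Among the measured compounds shown here, no measured pair shows this change alone. Compound 2 also carries acetoxy groups and gives 53500 nM but differs from compound 1 in more than one place, so it offers only a weak hint of a higher number. The expected step (a 1.3-fold higher number from compound 1 to compound 3 (0.11 log units; within the scatter)) is a modest rise in this assay that may stay within the scatter. For compound 3 the estimated value is 12000 nM (expected range 5000 nM to 30000 nM).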

Compound 3, half-maximal inhibitory concentration: 28600 nM
Compound 3: the middle estimate sits 2.4-fold (0.38 log units) below what was measured, within the range that was stated.
By their numbers in this assay, from the lowest: compound 1; then compounds 3 and 2 (each within the scatter of the next).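

Putting acetyl on the oxygen, with the rest of the core of compound 1 unchanged, gives a 3.0-fold higher number from compound 1 to compound 3 (0.48 log units; beyond the scatter) in this assay and so makes the compound a weaker inhibitor. This pair isolates the change from hydroxy to acetoxy, which the earlier comparison could not do, as compound 2 differs from compound 1 in more than one place. At this position the free hydroxy therefore gives the lower number, although the step is modest, and nothing available explains why the number rises.

From the compounds shown here alone, it remains open whether a methyl ether or a longer acyl chain such as butyryl on the same oxygen would follow acetyl. It is also unknown how an amine in place of the hydroxy would compare with compound 1.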